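Ethynyl for Thiophenyl on a Shared Nucleoside Core

A few compounds are considered here, and "the series" means these few. Any claim that something is new, unique, unknown or untested is made for them only; others in the source may bear on it.

Compound 1 `C#Cc1cn([C@@H]2O[C@H](CO)[C@@H](O)[C@H]2O)c2ncnc(C)c12` gives 5600 nM in a functional assay on CCRF-CEM cells (Homo sapiens), read by MTT assay, with a stated time of 72 h; a lower number here means a stronger inhibitor, a higher number a weaker inhibitor.
Compound 2 `COc1ncnc2c1c(-c1cccs1)cn2[C@@H]1O[C@H](CO)[C@@H](O)[C@H]1O` gives 90 nM in this assay.
Compound 3 `CNc1ncnc2c1c(-c1cccs1)cn2[C@@H]1O[C@H](CO)[C@@H](O)[C@H]1O` gives > 20000 nM in this assay.

Among the two numbers shown in this assay, compound 2 stands lowest, with compound 1 giving the clearly higher number. The value of compound 3 is a limit of the assay rather than a number. For the measured compounds named here, the only single-point step measured, an at least 220-fold higher number from compound 2 to compound 3 (2.34 log units; beyond the scatter), concerns the group on the six-membered ring and so does not bear directly on the change toward compound 4 `C#Cc1cn([C@@H]2O[C@H](CO)[C@@H](O)[C@H]2O)c2ncnc(OC)c12`. Going by the values given here, that change, (ethynyl in place of thiophen-2-yl on an aromatic carbon), has no measured counterpart here. Compound 1 carries the entering ethynyl, but it also differs from compound 2 in a second place, so its high number cannot be laid to the ethynyl alone; it does suggest that the ethynyl compounds shown are not the strong ones. Compound 4 is therefore estimated at 600 nM, between 80 nM and 5000 nM. This corresponds to an expected step of a 6.7-fold higher number from compound 2 to compound 4 (0.82 log units; beyond the scatter) toward weaker inhibition, though with wide uncertainty.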

Compound 4, half-maximal inhibitory concentration: > 20000 nM
Compound 4: no number, only a limit; the forecaster's own chance of this, stated with the estimate: 10%; at least 33-fold (1.52 log units) between middle value and limit.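

In this assay compound 4 gives > 20000 nM, which is a limit of the assay and not a number. Ethynyl in place of thiophen-2-yl on this aromatic carbon gives an at least 220-fold higher number from compound 2 to compound 4 (2.34 log units; beyond the scatter), so with methoxy held constant, the low number of compound 2 depends on the group at this position as well as on the methoxy shown to matter earlier. With ethynyl held constant, methoxy in place of methyl gives an at least 3.5-fold higher number from compound 1 to compound 4 (0.55 log units; beyond the scatter), so the methoxy that accompanies the low number alongside thiophen-2-yl does not bring a low number alongside ethynyl.

From the compounds shown here alone, the full size of both steps stays open, as each ends at a limit: the limit of > 20000 nM in this assay, at which 2 of the 4 values shown sit. Also open is whether another ring at this position, such as phenyl or furan-2-yl, would keep the number as low as thiophen-2-yl does.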